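A New Aryl Group on the Ring Nitrogen

The source may hold more compounds than are shown below. What is called first, only, known or untested is meant among the compounds shown, and "the series" means these compounds.

Compound 2 `COc1cc2c(Oc3ccc(NC(=O)c4cn(-c5ccccc5C)nn4)cc3F)ccnc2cc1OCCCN1CCCCC1` has been measured in a functional assay on NCI-H460 cells (Homo sapiens) for cytotoxicity, read by MTT assay, with a stated time of 72 h (a higher number here means a weaker inhibitor, a lower number a stronger inhibitor), where compound 2 gives 2100 nM. Going by the values given here, of the two numbers measured so far this is the top one, yet its only neighbour, compound 1 `COc1cc2c(Oc3ccc(NC(=O)c4cn(-c5ccccc5C)nn4)cc3F)ccnc2cc1OCCCN1CCCC1`, gives 1260 nM, and the step of a 1.7-fold higher number from compound 1 to compound 2 (0.22 log units; within the scatter) lies within the scatter, so the two compounds cannot be told apart. Compound 3 `COc1cc2c(Oc3ccc(NC(=O)c4cn(-c5ccc(F)c(F)c5)nn4)cc3F)ccnc2cc1OCCCN1CCCCC1` differs from compound 2 in one place only: 3,4-difluorophenyl in place of 2-methylphenyl on an aromatic nitrogen. Among the compounds with values here, the single measured step concerns the saturated chain at the far end of the shared core, not this ring nitrogen, so no measured step bears on the change made here. Without a guide, no step beyond the scatter is assumed, and compound 3 is expected to give about 2000 nM, within a range from 600 nM to 7000 nM. The step of a 1.1-fold lower number from compound 2 to compound 3 (0.02 log units; within the scatter) is therefore expected to be small, with wide uncertainty.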

Compound 3, half-maximal inhibitory concentration: 250 nM
Compound 3: middle estimate off by 8.0-fold (0.90 log units), on the high side; the measured number lies below the stated range.
By their numbers in this assay, from the lowest: compound 3; then compounds 1 and 2 (each within the scatter of the next).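

Going by these compounds alone, the aryl group on the aromatic nitrogen matters more than the earlier compounds could show: in this assay, 3,4-difluorophenyl in place of 2-methylphenyl gives an 8.4-fold lower number from compound 2 to compound 3 (0.92 log units; beyond the scatter) and so moves beyond the scatter. Within the data shown here, the only earlier step, at the far end of the saturated chain, stayed within it. Nothing available here accounts for this drop in the number.

The swap removes a methyl and adds two fluorines at once, and the compounds shown do not separate the two changes; an unsubstituted phenyl or a phenyl with a single fluorine would be needed for that. Also open, as far as these compounds go, is whether 3,4-difluorophenyl gives a similar step with pyrrolidin-1-yl or with a morpholine at the chain end.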